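The source may report more compounds than this note shows. Statements on the series, on what has been measured and on what is new or still open speak of the compounds shown alone.

For the measured compounds named here, in an assay for inhibition of tyrosine-protein kinase Mer (Homo sapiens), read by 33P incorporation, in the presence of a further agent that is not named here (on this read-out lower numbers stand for stronger inhibition and higher numbers for weaker inhibition), compound 1 `CNc1ncc2c(-c3ccc(N4CCNCC4)nc3)nn(Cc3cn(Cc4ccccc4)nn3)c2n1` gives 2300 nM, the lowest of the two numbers measured so far. Going by the values given here, compound 2 `CNc1ncc2c(-c3ccc(N4CCNCC4)nc3)nn(Cc3cn(-c4ccsc4C(=O)OC)nn3)c2n1` gives 8900 nM; the only measured step, a 3.9-fold higher number from compound 1 to compound 2 (0.59 log units; beyond the scatter), changes the group on an aromatic nitrogen and leaves the 6-(piperazin-1-yl)pyridin-3-yl group untouched. Compound 3 `CNc1ncc2c(-c3ccc(N4CCNCC4)cc3)nn(Cc3cn(Cc4ccccc4)nn3)c2n1` differs from compound 1 by 4-(piperazin-1-yl)phenyl in place of 6-(piperazin-1-yl)pyridin-3-yl on an aromatic carbon. Among the compounds with values here, no measured step bears on this change, so for compound 3 the expectation is a step within the scatter, a 1.1-fold higher number from compound 1 to compound 3 (0.04 log units; within the scatter), with an estimated value of 2500 nM and a range from 800 nM to 8000 nM.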

Compound 3, half-maximal inhibitory concentration: > 10000 nM
Compound 3: only a limit was reported (the forecaster's own chance of this, stated with the estimate: 5%); at least 4.0-fold (0.60 log units) between middle value and limit.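

Replacing 6-(piperazin-1-yl)pyridin-3-yl with 4-(piperazin-1-yl)phenyl, which puts carbon where the ring had a nitrogen, gives an at least 4.3-fold higher number from compound 1 to compound 3 (0.63 log units; beyond the scatter). In this assay compound 3 gives > 10000 nM, which is a limit and not a number. The earlier step touched only the group on an aromatic nitrogen, whereas this one shows that inhibition also weakens with a change on the aromatic carbon, and its full size cannot be read: the limit of > 10000 nM in this assay, at which 1 of the 3 values shown sits.

From the compounds shown here alone, whether the same swap weakens inhibition with the 2-(methoxycarbonyl)thiophen-3-yl group of compound 2 stays open. So does how a morpholine in place of the piperazine would read.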